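Solubility as the Amine Grows from Ring to Chain

The compounds below may be only part of what the source reports. "The series", "measured", "known", "first", "only" and "open" are said of these compounds alone.

Compound 3 `CC(C)(C)c1ccc2c(c1)[n+]([O-])c(NCCN1CCCCC1)n[n+]2[O-]` carries a piperidin-1-yl group at the end of its side chain. In a physicochemical assay for solubility, in the presence of a further agent that is not named here (a higher number here means a more soluble compound, a lower number a less soluble compound), compound 3 gives 28000000 nM. Compound 1 `CN(C)CCNc1n[n+]([O-])c2ccc(C(C)(C)C)cc2[n+]1[O-]` in this assay gives 38000000 nM; of these two numbers, compound 3 stands as the lower, though the step of a 1.4-fold lower number from compound 1 to compound 3 (0.13 log units; within the scatter) is too small to count as a difference. Compound 2 `CCN(CC)CCNc1n[n+]([O-])c2ccc(C(C)(C)C)cc2[n+]1[O-]` reaches only a limit of the assay, and in this assay compound 2 gives > 48000000 nM. That limit is described by the limit of > 48000000 nM in this assay, at which 1 of the 3 values shown sits.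

Compound 4 `CCCN(CCC)CCNc1n[n+]([O-])c2ccc(C(C)(C)C)cc2[n+]1[O-]` differs from compound 3 by dipropylamino in place of piperidin-1-yl on a saturated chain carbon, two bonds along the chain from a nitrogen on an aromatic ring. For the measured compounds named here, two measured steps bear on this: opening the ring towards a chain amine is seen in reverse in an at least 1.7-fold lower number from compound 2 to compound 3 (0.23 log units; that floor lies within the scatter), and lengthening chain amines in an at least 1.2-fold higher number from compound 1 to compound 2 (0.10 log units; that floor lies within the scatter). Both are small. The expected step is therefore a 1.5-fold higher number from compound 3 to compound 4 (0.18 log units; within the scatter), a modest rise that may stay within the scatter, with a fair chance that compound 4 also reaches the limit. Compound 4 is estimated to give 42000000 nM in this assay, expected to lie between 22000000 nM and 75000000 nM.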

Compound 4, solubility: 32000000 nM
Compound 4: the middle estimate sits 1.3-fold (0.12 log units) above what was measured; measured number inside the range.
By their numbers in this assay, from the lowest: compounds 3, 4 and 1 (each within the scatter of the next). At a limit, above all of these: compound 2.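

In this assay, the new compound shows that an open chain amine and a ring amine at the end of the side chain cannot be told apart, with a 1.1-fold higher number from compound 3 to compound 4 (0.06 log units; within the scatter). The longest chain amine shown and the shortest cannot be told apart either, with a 1.2-fold lower number from compound 1 to compound 4 (0.07 log units; within the scatter), so across compounds 1, 3 and 4, neither ring opening nor chain length gives a step beyond the scatter. The step of an at least 1.5-fold lower number from compound 2 to compound 4 (0.17 log units; that floor lies within the scatter) is only a floor, and it too separates nothing, since compound 2 gives a limit and not a number: the limit of > 48000000 nM in this assay, at which 1 of the 4 values shown sits.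

As far as these compounds go, it remains open whether any group at this position can move the number beyond the scatter. A morpholin-4-yl group or a carboxylic acid at the end of the side chain would test this with a different kind of group.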